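Lengthening the Butyl Chain of Compound 2 to Tetradecyl

The source may report more compounds than this note shows. Statements on the series, on what has been measured and on what is new or still open speak of the compounds shown alone.

- Compound 1 `COc1cccc(N(Cc2cn([C@@H]3O[C@H](COC(C)=O)[C@@H](OC(C)=O)[C@H]3OC(C)=O)nn2)S(C)(=O)=O)c1`: 190000 nM
- Compound 2 `CCCCN(Cc1cn([C@@H]2O[C@H](COC(C)=O)[C@@H](OC(C)=O)[C@H]2OC(C)=O)nn1)S(C)(=O)=O`: 250000 nM

In a functional assay on RCC4 cells (Homo sapiens) for antiproliferative activity, read by XTT assay, with a stated time of 48 h (on this read-out lower numbers stand for stronger inhibition and higher numbers for weaker inhibition), compound 2 gives 250000 nM, within the scatter of compound 1 at 190000 nM. Compound 3 `CCCCCCCCCCCCCCN(Cc1cn([C@@H]2O[C@H](COC(C)=O)[C@@H](OC(C)=O)[C@H]2OC(C)=O)nn1)S(C)(=O)=O` lengthens the butyl chain of compound 2: decyl in place of hydrogen on a saturated chain carbon, four bonds along the chain from a sulfonamide nitrogen. Within the data shown here, the only measured step, a 1.3-fold higher number from compound 1 to compound 2 (0.12 log units; within the scatter), offers weak guidance, since neither measured compound carries a chain of this length. The expected change, held loosely, is a 2.5-fold lower number from compound 2 to compound 3 (0.40 log units; beyond the scatter). For compound 3 the estimated value is 100000 nM, with an expected range of 20000 nM to 300000 nM.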

Compound 3, half-maximal inhibitory concentration: 29000 nM
For compound 3 the middle estimate is 3.4-fold (0.54 log units) above the measured one; low and high end bracket the measured number.
By their numbers in this assay, from the lowest: compound 3; then compounds 1 and 2 (each within the scatter of the next).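

In this assay, decyl in place of hydrogen on a saturated chain carbon, four bonds along the chain from a sulfonamide nitrogen, gives an 8.6-fold lower number from compound 2 to compound 3 (0.94 log units; beyond the scatter). Among these compounds, this is the first step beyond the scatter, and it shows that this position on the chain responds to added carbon. No measurement here accounts for the change.

With only butyl and tetradecyl chains shown, it remains open how an octyl or an octadecyl chain would compare. A terminal amine or carboxylic acid on the chain is also untested in what is shown.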